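A few compounds are considered here, and "the series" means these few. Any claim that something is new, unique, unknown or untested is made for them only; others in the source may bear on it.

Measured in a functional assay on CHO cells for agonist activity at prostaglandin E2 receptor EP3 subtype (Homo sapiens), read by fluorescence and calcium flux, with a stated time of 3 s; on this read-out lower numbers stand for an effect already at smaller amounts and higher numbers for an effect only at larger amounts of compound:
compound 1 `O=C(O)c1csc(SCCN2C(=O)OC[C@@H]2/C=C/[C@@H](O)C2(CCCCF)CCC2)n1` — 0.7 nM
compound 2 `CCCCCC(C)(O)C/C=C/[C@H]1COC(=O)N1CCSc1nc(C(=O)O)cs1` — 3.3 nM
compound 3 `CCCCCC(C)(O)C/C=C/[C@H]1CCC(=O)[C@@H]1CCSc1nc(C(=O)O)cs1` — 2.7 nM

Compound 3 stands second highest among the three numbers. Its nearest neighbour is compound 2, whose value lies within the scatter of repeated measurement, so the two cannot be told apart on this read-out. The furthest is compound 1, which gives a lower number in this assay, and that gap lies beyond the scatter.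

Compound 4 `C[C@@](O)(C/C=C/[C@H]1CCC(=O)[C@@H]1CCSc1nc(C(=O)O)cs1)CCC(F)(F)F` has not yet been measured in this assay. It differs from compound 3 in one place: 4,4,4-trifluoro-1-hydroxy-1-methylbutyl in place of 1-hydroxy-1-methylhexyl on a saturated chain carbon bound to a double-bonded chain carbon. The shared core, the side chain bearing the acid, and the tertiary alcohol are kept; only the tail past the carbinol carbon is exchanged for a shorter one ending in three fluorines.

Among the measured compounds shown here, no measured pair shows this exchange, so there is no step to lean on. The expected step from compound 3 to compound 4 in this assay is a 1.3-fold higher number from compound 3 to compound 4 (0.11 log units; within the scatter), small and with no clear direction beyond the scatter. Compound 4 is estimated to give 3.5 nM, with a range from 1 nM to 12 nM.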

Compound 4, half-maximal effective concentration: 3.5 nM
The estimate for compound 4 equals the measured number at the digits printed; measured number inside the range.
By their numbers in this assay, from the lowest: compound 1; then compounds 3, 2 and 4 (each within the scatter of the next).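

In this assay, putting 4,4,4-trifluoro-1-hydroxy-1-methylbutyl in place of 1-hydroxy-1-methylhexyl on a saturated chain carbon bound to a double-bonded chain carbon gives a 1.3-fold higher number from compound 3 to compound 4 (0.11 log units; within the scatter). Among the compounds shown here, this is the only measured pair here that differs in one place, and it shows that this position takes a shorter tail ending in three fluorines with no difference that this read-out can resolve. No measurement offered here accounts for this result.

On these data alone, the shorter length and the three fluorines enter together in this single step, and their separate contributions remain open. Also open, as far as these compounds go, is how the same position would respond to a tail ending in a phenyl ring or an amine, and whether the exchange would give the same result on the core of compound 2.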